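Halogen exchange on the benzylamine arm of compound 2

The compounds below may be only part of what the source reports. "The series", "measured", "known", "first", "only" and "open" are said of these compounds alone.

Two compounds in this series have numbers in a functional assay on HT-29 cells (Homo sapiens) for inhibition, read by MTT assay, with a stated time of 72 h; a higher number here means a weaker inhibitor, a lower number a stronger inhibitor. Compound 1, `COc1ccc(CCCNCc2c(OC)cc(Oc3ccc(Nc4ccccc4)cc3)cc2OC)cc1`, gives 6890 nM. Compound 2, `COc1cc(Oc2cccc(Nc3ccccc3)c2)cc(OC)c1CNCc1ccc(Cl)cc1`, gives 3350 nM, the lower of the two numbers, and the gap to compound 1 lies beyond the scatter. The two structures differ in several places, so their values stand side by side without a step between them.

Compound 3, `COc1cc(Oc2cccc(Nc3ccccc3)c2)cc(OC)c1CNCc1ccc(Br)cc1`, is the next member to be measured in this assay. Its change from compound 2 is bromo in place of chloro on an aromatic carbon. One halogen replaces another on the same aromatic carbon, with no change in ring count, donors, acceptors or charge. Going by the values given here, no measured pair shows the effect of such an exchange, so there is no step to lean on. The expected step of a 1.1-fold lower number from compound 2 to compound 3 (0.05 log units; within the scatter) is small, well within the scatter, with no preferred direction. Compound 3 is estimated at 3000 nM in this assay, with a range from 1300 nM to 7000 nM.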

Compound 3, half-maximal inhibitory concentration: 3060 nM
Estimate against measurement, compound 3: 1.0-fold (0.01 log units) below, and the stated range covers the measured number.
By their numbers in this assay, from the lowest: compounds 3 and 2 (each within the scatter of the next); then compound 1.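

In this assay, going by these compounds alone, the exchange on the benzylamine arm gives the first single-place step, a 1.1-fold lower number from compound 2 to compound 3 (0.04 log units; within the scatter). At this aromatic carbon, para to a large group, the 4-chlorobenzyl and 4-bromobenzyl forms therefore cannot be told apart in this read-out, and either halogen is compatible with a number in the same range. Nothing in hand speaks to why the two halogens read alike.

Within the data shown here, the step covers only one halogen exchange, so how far this carbon responds to substitution remains open: a nitrile, a carboxylic acid or a primary amine at the same carbon, or an unsubstituted benzyl arm, could show whether the number moves beyond the scatter. Compound 1 differs from both halogen compounds in several places, so its value gives no reading on this carbon, and the separate contributions of its longer chain and its different ring substitution also remain unresolved.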